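Longer amide chain on a shared nucleoside core

The compounds below may be only part of what the source reports. "The series", "measured", "known", "first", "only" and "open" are said of these compounds alone.

Compound 1, `CCCCCCCCCC(=O)Nc1ccn([C@@H]2CO[C@H](CO)O2)c(=O)n1` — in a functional assay on SW1573 cells (Homo sapiens) for cytotoxicity, read by sulforhodamine B assay, with a stated time of 72 h (on this read-out higher numbers stand for weaker inhibition and lower numbers for stronger inhibition), compound 1 gives 40 nM
Compound 2, `CCCCCCCCCCCCCCCCCC(=O)Nc1ccn([C@@H]2CO[C@H](CO)O2)c(=O)n1` — compound 2 gives 125 nM
Compound 3, `CCCCCCCCCCCCCCCCCCCC(=O)Nc1ccn([C@@H]2CO[C@H](CO)O2)c(=O)n1` — not yet measured

Within the data shown here, of the two measured compounds, compound 2 has the higher number, meaning the weaker inhibition; its only neighbour is compound 1, and the change between them is a 3.1-fold higher number from compound 1 to compound 2 (0.49 log units; beyond the scatter). That step comes from adding octyl to the saturated chain of the amide.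

Compound 3 continues in the same direction: ethyl in place of hydrogen on a saturated chain carbon, ten or more bonds along the chain from a carbonyl carbon. Among the measured compounds shown here, the one step that bears on this change is a 3.1-fold higher number from compound 1 to compound 2 (0.49 log units; beyond the scatter), which was modest and ran toward a higher number when a much larger piece of chain was added. The addition here is smaller, ethyl rather than octyl, so a smaller push of the same kind is expected, quite possibly one that stays within the scatter.

Compound 3 is therefore estimated at 170 nM, with a range from 80 nM to 400 nM. The expected step is a 1.4-fold higher number from compound 2 to compound 3 (0.13 log units; within the scatter), a slight move toward weaker inhibition.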

Compound 3, half-maximal inhibitory concentration: 150 nM
Estimate against measurement, compound 3: 1.1-fold (0.05 log units) above, and the stated range covers the measured number.
By their numbers in this assay, from the lowest: compound 1; then compounds 2 and 3 (each within the scatter of the next).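

Adding ethyl on a saturated chain carbon gives in this assay a 1.2-fold higher number from compound 2 to compound 3 (0.08 log units; within the scatter) and so produces no change that can be told apart from ordinary repeat-to-repeat variation. The full lengthening by decyl still gives a 3.8-fold higher number from compound 1 to compound 3 (0.57 log units; beyond the scatter) and remains a real but modest difference, so compound 3 stays separated from compound 1 while compound 2 and compound 3 cannot be ranked against each other. Among these compounds, the single earlier step could not show whether each further piece of chain would keep raising the number; here, the last ethyl gives no measurable rise, although three compounds are too few to establish a plateau.

Nothing measured here explains why the chain behaves this way in these cells. Going by these compounds, it also remains open whether a shorter chain would give a lower or higher number than compound 1, and whether an amine or a carboxylic acid on the chain would change the result.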